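A few compounds are considered here, and "the series" means these few. Any claim that something is new, unique, unknown or untested is made for them only; others in the source may bear on it.

Measured so far: compound 1 `O=C1c2ccccc2N(Cc2ccccc2)S(=O)(=O)N1Cc1ccc(Cl)cc1` with 27800 nM; compound 2 `O=C1c2ccccc2N(Cc2ccc(Cl)c(Cl)c2)S(=O)(=O)N1Cc1ccccc1` with 16400 nM.

In a functional assay on CCRF-CEM cells (Homo sapiens) for inhibition (a higher number here means that more compound is tolerated, a lower number that less compound is tolerated), compound 1 gives 27800 nM. Compound 2 gives 16400 nM, and the gap to compound 1 lies within the scatter of repeated measurements, so the two are not separated. Compound 3 `O=C1c2ccccc2N(Cc2ccccc2)S(=O)(=O)N1Cc1ccccc1Cl` has not yet been measured in this assay. It differs from compound 1 by 2-chlorophenyl in place of 4-chlorophenyl on a saturated chain carbon bound to an amide-type nitrogen in a ring. Within the data shown here, no step between measured compounds tests this change. For compound 3 the step of a 1.1-fold lower number from compound 1 to compound 3 (0.05 log units; within the scatter) is expected to stay within the scatter, with no clear direction. Compound 3 is estimated at 25000 nM, range 10000 nM to 60000 nM.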

Compound 3, half-maximal cytotoxic concentration: > 250000 nM
Compound 3 was reported as a limit; the forecaster's own chance of this, stated with the estimate: 10%; middle value at least 10-fold (1.00 log units) away from the limit.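

The chlorine's place on the benzyl group is not neutral in this series: 2-chlorophenyl in place of 4-chlorophenyl, with the same atoms, gives an at least 8.9-fold higher number from compound 1 to compound 3 (0.95 log units; beyond the scatter) in this assay. Among these compounds, neither of the earlier compounds tested this change, and it is the first step beyond the scatter. Compound 3 stands at a limit of the assay, not at a number: the limit of > 250000 nM in this assay, at which 1 of the 3 values shown sits.

From the compounds shown here alone, the full size of the step therefore stays open. Also open, going by these compounds, is whether a pyridine ring or a carboxylic acid at this place would give a number within range.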